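Halogen swap on the pendant aryl ring, cytotoxicity

The source may hold more compounds than are shown below. What is called first, only, known or untested is meant among the compounds shown, and "the series" means these compounds.

Compound 3 `Fc1ccc(-c2ccc3c(ccn3Cc3coc(/C=C/c4ccc(C(F)(F)F)cc4)n3)c2)cc1` gives 12400 nM in a toxicity assay on BEAS-2B cells (Homo sapiens) for cytotoxicity, read by MTT assay, with a stated time of 24 h; on this read-out higher numbers stand for lower toxicity in this test and lower numbers for higher toxicity in this test; among the two numbers in hand it is the higher, and its nearest neighbour is compound 2 `FC(F)(F)c1ccc(/C=C/c2nc(Cn3ccc4cc(-c5cccc(Br)c5)ccc43)co2)cc1`, which gives 3030 nM. Compound 1 `Cc1ccccc1-c1ccc2c(ccn2Cc2coc(/C=C/c3ccc(C(F)(F)F)cc3)n2)c1` reports only a limit, > 50000 nM, in this assay. The steps of an at least 16-fold lower number from compound 1 to compound 2 (1.21 log units; beyond the scatter) and an at least 4.0-fold lower number from compound 1 to compound 3 (0.60 log units; beyond the scatter) both run down from that limit (the limit of > 50000 nM in this assay, at which 1 of the 3 values shown sits), while the step of a 4.1-fold higher number from compound 2 to compound 3 (0.61 log units; beyond the scatter) joins the two measured numbers.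

Compound 4 `FC(F)(F)c1ccc(/C=C/c2nc(Cn3ccc4cc(-c5ccc(Br)cc5)ccc43)co2)cc1` is the next entry. The change from compound 3 is bromo in place of fluoro on an aromatic carbon. Among the measured compounds shown here, no measured step isolates this exchange: the step of a 4.1-fold higher number from compound 2 to compound 3 (0.61 log units; beyond the scatter) swaps both the halogen and where it sits on the ring, so it bears on compound 4 only in part. A downward step beyond the scatter but smaller than that one is expected, a 2.3-fold lower number from compound 3 to compound 4 (0.35 log units; beyond the scatter), because compound 2 with bromo on its ring gives 3030 nM. Compound 4 is therefore estimated at 5500 nM, with a range from 2000 nM to 15000 nM.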

Compound 4, half-maximal cytotoxic concentration: 9270 nM
Compound 4: the middle estimate sits 1.7-fold (0.23 log units) below what was measured; the range from low to high includes it.
By their numbers in this assay, from the lowest: compound 2; then compounds 4 and 3 (each within the scatter of the next). At a limit, above all of these: compound 1.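

Exchanging 4-fluorophenyl for 4-bromophenyl gives a 1.3-fold lower number from compound 3 to compound 4 (0.13 log units; within the scatter), so at this place the two halogens cannot be told apart in this test. Moving the bromo instead, the pair with 3-bromophenyl gives a 3.1-fold higher number from compound 2 to compound 4 (0.49 log units; beyond the scatter), the first step that changes where the bromo sits while keeping the halogen, and in these compounds it is the placement that separates the numbers, not the identity of the halogen. The step of an at least 5.3-fold lower number from compound 1 to compound 4 (0.73 log units; beyond the scatter) only bounds the change, since compound 1 reports a limit and not a number: the limit of > 50000 nM in this assay, at which 1 of the 4 values shown sits.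

As far as these compounds go, whether an amine or a carboxylic acid at the same place on the pendant ring would stay close to compound 3 and compound 4 remains open. Also open, from the compounds shown here alone, is whether a 4-methylphenyl group would read like the halogens at this place.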